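The source may hold more compounds than are shown below. What is called first, only, known or untested is meant among the compounds shown, and "the series" means these compounds.

Compound 1, `COc1ccc(-c2cc(/C=C/C(=O)c3ccc(N)cc3)[nH]n2)cc1`, was tested in a functional assay on OVCAR-4 cells (Homo sapiens) for cytotoxicity, read by sulforhodamine B assay, with a stated time of 48 h, tested at 100 uM (a higher number here means a weaker effect of the compound at the concentration tested, a lower number a stronger effect), and gave -68%. Among the measured compounds shown here, the only other measured compound, compound 2, `COc1cc(-c2cc(/C=C/C(=O)c3ccc(Cl)c(Cl)c3)[nH]n2)cc(OC)c1OC`, gave -22% in this assay. For the measured compounds named here, the two compounds differ in more than one place, so no single step connects them; what their two numbers show is that compound 1 sits lower, by a gap beyond the usual scatter, and it is therefore the lowest of the two values at hand. Compound 3, `COc1ccc(-c2cc(/C=C/C(=O)c3ccc(N)cc3)[nH]n2)cc1OC`, has not yet been measured. It differs from compound 1 by methoxy in place of hydrogen on an aromatic carbon, the entering group sitting on a six-membered aromatic ring of carbon only, ortho to a methoxy group already present and meta to a large group. Going by the values given here, with no step between measured compounds that isolates this change, the expected step of a number 8 percentage points higher from compound 1 to compound 3 (within the scatter) is small, and no direction beyond the scatter is firmly supported by the data at hand. For compound 3 the estimated value in this assay is -60%, with a range from -90% to -25%.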

Compound 3, a percentage reported as activity, at one concentration (the size of the read-out at that concentration, not a potency): -98%
The estimate for compound 3 lay 38 percentage points above the measured number, outside the stated range (below it).
By their numbers in this assay, from the lowest: compound 3; then compound 1; then compound 2.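

Among the compounds shown here, the hydrogen-to-methoxy change gives the first comparison in this set that differs in one place: in this assay, it produces a number 30 percentage points lower from compound 1 to compound 3 (beyond the scatter). The position on the six-membered aromatic ring, ortho to a methoxy group and meta to a large group, is therefore one where this small substitution alters the read-out measurably, and compound 3, at -98%, now holds the lowest of the three numbers at hand. No measured information accompanies this step that could account for it, so the result stands as an observation about this one change on the core of compound 1.

The compounds shown leave open whether the step is specific to methoxy or would also appear with another group at the same place, such as a hydroxyl group, a fluorine atom or an ethoxy group. They also leave open whether the same change would have a similar effect if the amine of compound 1 were replaced by another group, such as a chlorine atom or a carboxylic acid.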